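Trading One Fluorine for Hydrogen in a Permeability Series

The source may report more compounds than this note shows. Statements on the series, on what has been measured and on what is new or still open speak of the compounds shown alone.

Measured compounds:
compound 1, `Fc1ccccc1Cc1nc(-c2nc(C(F)(F)F)n[nH]2)n2ccccc12`: 6 10^-6 cm/s
compound 2, `Cc1ncc(Cc2nc(-c3nc(C(F)(F)F)n[nH]3)n3cccc(F)c23)cn1`: 23 10^-6 cm/s
compound 3, `Fc1ccccc1Cc1nc(-c2nc(C(F)(F)F)n[nH]2)n2cccnc12`: 28 10^-6 cm/s

In an ADME assay on MDCKII-LE cells (Canis lupus familiaris) for permeability, in the apical to basolateral direction (on this read-out higher numbers stand for higher permeability and lower numbers for lower permeability), compound 1 gives 6 10^-6 cm/s, the lowest of the three numbers. Compound 2 gives 23 10^-6 cm/s and compound 3 gives 28 10^-6 cm/s; both of these lie beyond the scatter above compound 1. Neither compound 2 nor compound 3 differs from compound 1 in a single place, so their gaps to compound 1 cannot be read as single steps, and they say nothing direct about the change considered here.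

Compound 4, `Fc1ccccc1Cc1nc(-c2nc(C(F)F)n[nH]2)n2ccccc12`, has not yet been measured. It differs from compound 1 in exactly one place: hydrogen in place of fluoro on a saturated chain carbon bound to an aromatic carbon and two fluorine atoms. For the measured compounds named here, no measured pair in this set shows this change, so there is no step to lean on. The change is small in what it counts, one fluorine leaving and a hydrogen entering on a saturated chain carbon, and nothing in the measured numbers points in a particular direction. The step from compound 1 to compound 4 in this assay is therefore expected to be small, a 1.2-fold lower number from compound 1 to compound 4 (0.08 log units; within the scatter), and not beyond the scatter in either direction. Compound 4 is estimated at 5 10^-6 cm/s, with a range from 2.5 10^-6 cm/s to 10 10^-6 cm/s.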

Compound 4, apparent permeability: 0.2 10^-6 cm/s
Compound 4: the middle estimate sits 25-fold (1.40 log units) above what was measured; measured number outside the range, below it.
By their numbers in this assay, from the lowest: compound 4; then compound 1; then compounds 2 and 3 (each within the scatter of the next).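

In this assay, the group on the triazole-free reading of the core is best left aside: what matters is that going from trifluoromethyl to difluoromethyl, one hydrogen in place of fluoro on a saturated chain carbon bound to an aromatic carbon and two fluorine atoms, gives a 30-fold lower number from compound 1 to compound 4 (1.48 log units; beyond the scatter), a large step well beyond the scatter. For the compounds shown here, the earlier compounds offered no step in one place at all, so this is the first direct sign that the number in this assay can answer strongly at this position, and that a change of a single atom here is not a minor edit. Nothing available here accounts for the size of this step, and no measurement of any property of the two compounds bears on it.

What the compounds shown leave open is whether the steep fall belongs to this particular change or to the position more generally, since a methyl group or a longer chain such as ethyl at the same place would speak to that. They also leave open whether the same change would give a step of similar size on the cores of compound 2 and compound 3.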